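Branching the Acyl Chain of a Trimethoxyphenyl Amide Series

This account rests on a few compounds, and the source may have more. Where it says the series, first, only, none or still open, it means among the compounds named here.

Three amides share one core and differ only in the acyl group. In a functional assay on KYSE-450 cells (Homo sapiens) for inhibition, read by MTT assay, with a stated time of 48 h (on this read-out higher numbers stand for weaker inhibition and lower numbers for stronger inhibition), compound 1 `CCCCC(=O)N(Cc1ccc(OC)c(O)c1)c1cc(OC)c(OC)c(OC)c1` gives 300 nM, compound 2 `COCC(=O)N(Cc1ccc(OC)c(O)c1)c1cc(OC)c(OC)c(OC)c1` gives 460 nM, and compound 3 `CCC(=O)N(Cc1ccc(OC)c(O)c1)c1cc(OC)c(OC)c(OC)c1` gives 98 nM. Compound 3 stands lowest of the three and is the strongest inhibitor shown: the steps of a 3.1-fold lower number from compound 1 to compound 3 (0.49 log units; beyond the scatter) and a 4.7-fold lower number from compound 2 to compound 3 (0.67 log units; beyond the scatter) both reach beyond the scatter, while the step of a 1.5-fold higher number from compound 1 to compound 2 (0.19 log units; within the scatter) stays within it. Compound 4 `COc1ccc(CN(C(=O)C(C)C)c2cc(OC)c(OC)c(OC)c2)cc1O` differs from compound 3 by methyl in place of hydrogen on a saturated chain carbon bound to a carbonyl carbon and a saturated chain carbon. The step that bears most on this change runs along the same acyl chain: a 3.1-fold lower number from compound 1 to compound 3 (0.49 log units; beyond the scatter) shows that a shorter chain went with a lower number, so growing the chain again with the entering methyl is expected to push the number modestly upward, though less far than that step. Compound 4 is therefore expected to give 200 nM, with a range from 80 nM to 500 nM. This estimate means an expected step of a 2.0-fold higher number from compound 3 to compound 4 (0.31 log units; beyond the scatter).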

Compound 4, half-maximal inhibitory concentration: 390 nM
Beside the measured number, compound 4's estimate is 2.0-fold (0.29 log units) below it, and the stated range covers the measured number.
By their numbers in this assay, from the lowest: compound 3; then compounds 1, 4 and 2 (each within the scatter of the next).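

The propanoyl-to-isopropylcarbonyl change at this saturated chain carbon gives a 4.0-fold higher number from compound 3 to compound 4 (0.60 log units; beyond the scatter) in this assay and shows that one entering methyl is enough to lose the advantage of the propanoyl amide, which leaves compound 3 the strongest inhibitor of the four. The earlier compounds shown here varied the chain only by length or by methoxy, while this result shows that branching also matters: the isopropyl amide does not separate from the other acyl groups, with a 1.2-fold lower number from compound 2 to compound 4 (0.07 log units; within the scatter) and a 1.3-fold higher number from compound 1 to compound 4 (0.11 log units; within the scatter) both staying within the scatter. No measurement shown explains why the number rises at this carbon.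

The compounds shown leave open how a cyclopropyl or tert-butyl group on the carbonyl carbon would read. They also leave open whether an acetyl group, shorter than propanoyl, would give a lower or a higher number.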